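Aryl amine swap on the shared core: from compound 3 to compound 4

The source may hold more compounds than are shown below. What is called first, only, known or untested is meant among the compounds shown, and "the series" means these compounds.

Measured compounds:
compound 1 `O=C1C(Nc2ccc(Br)cc2)=CC(=O)c2c1nc1n2[C@H]2OC[C@@H](O)[C@H]2OC1` — 1980 nM
compound 2 `Cc1ccc(NC2=CC(=O)c3c(nc4n3[C@H]3OC[C@@H](O)[C@H]3OC4)C2=O)cc1` — > 4000 nM
compound 3 `COc1ccccc1NC1=CC(=O)c2nc3n(c2C1=O)[C@H]1OC[C@@H](O)[C@H]1OC3` — > 4000 nM

In a functional assay on ECa-109 cells for inhibition, with ECa-109 cell line (Homo sapiens) as the target, read by sulforhodamine B assay (on this read-out lower numbers stand for stronger inhibition and higher numbers for weaker inhibition), compound 1 gives 1980 nM. For compound 2 the result is only a limit of the assay, > 4000 nM. For compound 3 the result is likewise a limit and not a number, > 4000 nM. Compound 3 therefore stands at the limit of > 4000 nM in this assay, at which 2 of the 3 values shown sit, so its true value is not pinned down.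

Compound 4 `O=C1C=C(Nc2ccc(I)cc2)C(=O)c2c1nc1n2[C@H]2OC[C@@H](O)[C@H]2OC1` is built from compound 3 by 4-iodophenyl in place of 2-methoxyphenyl on an amine nitrogen. For the measured compounds named here, the only measured step that touches this region is an at least 2.0-fold higher number from compound 1 to compound 2 (0.30 log units; that floor lies within the scatter), where a methyl replaced a halogen on the ring and the number rose to the limit. Going by the values given here, no measured step exchanges a 2-methoxyphenyl for a ring bearing a halogen, so the expectation rests on compound 1, whose 4-bromophenyl gave 1980 nM. Since compound 4 carries a 4-iodophenyl, the nearest measured relative is compound 1 rather than compound 3, and a number below the limit is expected, with an at least 2.0-fold lower number from compound 3 to compound 4 (0.30 log units; that floor lies within the scatter) as the estimated step. Compound 4 is thus expected to give about 2000 nM, between 800 nM and 4000 nM.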

Compound 4, half-maximal inhibitory concentration: 2300 nM
For compound 4 the middle estimate is 1.2-fold (0.06 log units) below the measured one; the measured number falls inside the stated range.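

In this assay, exchanging 2-methoxyphenyl for 4-iodophenyl on the amine nitrogen gives an at least 1.7-fold lower number from compound 3 to compound 4 (0.24 log units; that floor lies within the scatter), which is a floor and not the full size of the change. Compound 3 stands at a limit of the assay, > 4000 nM, and not at a number. The new result adds a second halogen-bearing ring to the series that reads as a number rather than a limit: compound 1 with its 4-bromophenyl gives 1980 nM, and compound 4 with its 4-iodophenyl gives 2300 nM.

The swap replaces both the substituent and the name position it carries, so the compounds shown do not separate the two, and they leave open what an unsubstituted phenyl, or a ring bearing chloro or a carboxylic acid in place of the iodo, would give in this assay. How far compound 2 and compound 3 truly lie from the two halogen-bearing compounds also stays unread: the limit of > 4000 nM in this assay, at which 2 of the 4 values shown sit.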